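This account rests on a few compounds, and the source may have more. Where it says the series, first, only, none or still open, it means among the compounds named here.

Measured compounds:
Compound 1, `NC(=O)c1cc(Cl)c2c(Cl)c(C#CC3CCOCC3)n([C@H]3CCCNC3)c2n1`: 440 ng.h/mL
Compound 2, `COCCC#Cc1c(Cl)c2c(Cl)cc(C(N)=O)nc2n1[C@H]1CCCNC1`: 405 ng.h/mL

In an ADME assay on the whole organism (Rattus norvegicus) for pharmacokinetics, at a dose of 3 mg/kg by the intravenous route (a lower number here means less compound in the circulation, a higher number more compound in the circulation at the dose given), compound 2 gives 405 ng.h/mL. Among the measured compounds shown here, only one other compound has been measured here, compound 1, which gives 440 ng.h/mL; the two numbers sit within the scatter of each other, so neither can be said to stand apart from the other. For the measured compounds named here, the single measured step, a 1.1-fold lower number from compound 1 to compound 2 (0.04 log units; within the scatter), exchanged one group carrying a single hydrogen-bond acceptor for another at the triple-bonded carbon and left the number where it was.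

Compound 3, `NC(=O)c1cc(Cl)c2c(Cl)c(C#CC3CCCO3)n([C@H]3CCCNC3)c2n1`, differs from compound 2 by oxolan-2-yl in place of 2-methoxyethyl on a triple-bonded carbon. Again one group with one hydrogen-bond acceptor replaces another at the same triple-bonded carbon, so that step is the only guide, and it bears directly on this change. On that basis the expected step is a 1.0-fold higher number from compound 2 to compound 3 (0.02 log units; within the scatter), nothing beyond the scatter. Compound 3 is therefore estimated at 420 ng.h/mL, with a likely range from 200 ng.h/mL to 850 ng.h/mL.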

Compound 3, area under the concentration-time curve: 324 ng.h/mL
Compound 3: the middle estimate sits 1.3-fold (0.11 log units) above what was measured; measured number inside the range.
By their numbers in this assay, from the lowest: compounds 3, 2 and 1 (each within the scatter of the next).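

At the triple-bonded carbon, the comparison now includes two rings and an open chain. In this assay, replacing the open 2-methoxyethyl chain with the five-membered oxolan-2-yl ring gives a 1.3-fold lower number from compound 2 to compound 3 (0.10 log units; within the scatter), and replacing the oxan-4-yl ring with oxolan-2-yl gives a 1.4-fold lower number from compound 1 to compound 3 (0.13 log units; within the scatter), so among these three compounds neither adding this ring nor changing between these two rings produces a step beyond the scatter. No measurement is available to explain these small differences.

Going by these compounds, all three groups carry one oxygen and no charge, so it remains open whether a group without oxygen, such as cyclopentyl, would give a step beyond the scatter at this carbon. The same question stands for an amine, a carboxylic acid or a longer chain in this place.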